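A fluoro compound drawn without its double-bond configuration

This account rests on a few compounds, and the source may have more. Where it says the series, first, only, none or still open, it means among the compounds named here.

In a functional assay on U-87MG ATCC cells (Homo sapiens) for cytotoxicity, read by MTT assay, with a stated time of 48 h (on this read-out higher numbers stand for weaker inhibition and lower numbers for stronger inhibition), compound 1 `C/C(=N/NC(=S)Nc1ccccc1)c1ccccn1` gives 1.4 nM and compound 2 `C/C(=N/NC(=S)Nc1ccc(Cl)cc1)c1ccccn1` gives 1.7 nM, a pair within the scatter, with a 1.2-fold higher number from compound 1 to compound 2 (0.08 log units; within the scatter). Compound 3 `C/C(=N/NC(=S)Nc1ccc(F)cc1)c1ccccn1`, at 10 nM, has the highest number of the three, with a 7.1-fold higher number from compound 1 to compound 3 (0.85 log units; beyond the scatter) and a 5.9-fold higher number from compound 2 to compound 3 (0.77 log units; beyond the scatter). Compound 4 `CC(=NNC(=S)Nc1ccc(F)cc1)c1ccccn1` differs from compound 3 only in how it is drawn: the two compounds have the same atoms and bonds; at least one stereo element is drawn with a configuration in one of them and without one in the other: 1 of 1 stereo elements differ; a double bond is drawn Z in compound 3 and without a configuration in compound 4. Among the compounds with values here, all the measured steps swap a group on an aromatic carbon, and none touches a double bond's configuration, so none gives a size for this change. With atoms and bonds unchanged, the expected result is no change at the digits printed from compound 3 to compound 4 (within the scatter), nothing beyond the scatter. For compound 4 the estimated value is 10 nM, with an expected range from 4 nM to 25 nM.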

Compound 4, half-maximal inhibitory concentration: 10 nM
Beside the measured number, compound 4's estimate shows no gap at the digits printed; measured number inside the range.
By their numbers in this assay, from the lowest: compounds 1 and 2 (each within the scatter of the next); then compounds 3 and 4 (each within the scatter of the next).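

In this assay, how the double bond is drawn makes no visible difference, with no change at the digits printed from compound 3 to compound 4 (within the scatter). Within the data shown here, the earlier steps all swapped a group on an aromatic carbon, so this is the first reading at the double bond, and it concerns a drawing rather than a change of atoms: the fact that one of compounds 3 and 4 is drawn with a defined configuration and the other without, at the place where they differ.

These numbers cannot tell whether compound 3 and compound 4 are the same material or whether compound 4 is a mixture of double-bond forms. As far as these compounds go, how a bromo, methoxy or amine group on the aromatic carbon would compare with the fluoro of compound 3 also remains open.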